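Lengthening the sulfur chain of compound 3

A few compounds are considered here, and "the series" means these few. Any claim that something is new, unique, unknown or untested is made for them only; others in the source may bear on it.

Measured in a functional assay on HepG2 cells (Homo sapiens) for inhibition, read by MTT assay, with a stated time of 48 h; on this read-out lower numbers stand for stronger inhibition and higher numbers for weaker inhibition:
compound 1 `CCSc1nnc(-c2cc(OC)c(OC)c(OC)c2)n1-c1ccc(OC)cc1` gives > 60000 nM (a limit)
compound 2 `COc1ccc(-n2c(SCc3ccccc3)nnc2-c2cc(OC)c(OC)c(OC)c2)cc1` gives > 60000 nM (a limit)
compound 3 `CCSc1nnc(-c2cc(OC)c(OC)c(OC)c2)n1-c1ccc(N(C)C)cc1` gives > 60000 nM (a limit)

In this assay compound 3 gives > 60000 nM, which is a limit and not a number. Among the measured compounds shown here, it stands level with the other two compounds on this one point (the limit of > 60000 nM in this assay, at which 3 of the 3 values shown sit) , so no measured compound here has a true number.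

Compound 4 `COc1ccc(C(=O)CSc2nnc(-c3cc(OC)c(OC)c(OC)c3)n2-c2ccc(N(C)C)cc2)cc1` differs from compound 3 in one place: (4-methoxyphenyl)carbonyl in place of methyl on a saturated chain carbon bound to a sulfur.

For the measured compounds named here, two measured steps bear on this change. The nearer one, at the same kind of carbon, is a step that the two limits leave unreadable from compound 1 to compound 2, with phenyl in place of methyl. The other, with dimethylamino in place of methoxy on an aromatic carbon, is a step that the two limits leave unreadable from compound 1 to compound 3. Neither has a readable size, so neither fixes the size or direction of the new step. Going by the values given here, no compound measured here carries the entering carbonyl.

A modest move toward stronger inhibition is tentatively expected, and compound 4 may well stay at a limit too. The expected step is an at least 2.4-fold lower number from compound 3 to compound 4 (0.38 log units; beyond the scatter). For compound 4 the estimated value is 25000 nM, with an expected range from 3000 nM to 60000 nM.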

Compound 4, half-maximal inhibitory concentration: 18800 nM
The estimate for compound 4 lay 1.3-fold (0.12 log units) above the measured number, and the stated range covers the measured number.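

Swapping methyl for (4-methoxyphenyl)carbonyl on the saturated chain carbon bound to a sulfur gives, in this assay, an at least 3.1-fold lower number from compound 3 to compound 4 (0.50 log units; beyond the scatter). Among the compounds shown here, this is the first step at this position with a readable direction, as the earlier steps all run between limits and cannot be read, and it shows that a change at this carbon can bring a compound of this series out of the limit and onto a true number. Its full size remains unknown because the starting value is a limit and not a number: the limit of > 60000 nM in this assay, at which 3 of the 4 values shown sit.

The entering group brings a carbonyl and a methoxy-bearing aromatic ring together, so the compounds shown cannot say which part carries the step, or whether a plain ketone such as acetyl, a carboxylic acid or a longer chain at this carbon would do the same. Going by these compounds, it also remains open whether the step depends on the dimethylamino group elsewhere in the molecule, and whether replacing the methoxy on the entering ring with a fluorine or a hydroxyl would move the number further in either direction.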